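The compounds below may be only part of what the source reports. "The series", "measured", "known", "first", "only" and "open" are said of these compounds alone.

Measured compounds in a functional assay on PC-3 cells (Homo sapiens) for inhibition, read by MTT assay, with a stated time of 72 h; on this read-out lower numbers stand for stronger inhibition and higher numbers for weaker inhibition:
- compound 1 `O=C(CSc1nc(Nc2ccccc2)c2ccccc2n1)Nc1ccccc1Cl` gives 14600 nM
- compound 2 `O=C(CSc1nc(Nc2ccccc2)c2ccccc2n1)Nc1ccc(Cl)cc1` gives 12900 nM
- compound 3 `C=CC(=O)Nc1cccc(NC(=O)CSc2nc(Nc3cccc(Br)c3)c3ccccc3n2)c1` gives 15000 nM

The three numbers sit within the scatter of one another, so compound 3 stands level with compound 1 and compound 2 rather than apart from them. Among the measured compounds shown here, the one measured step, a 1.1-fold lower number from compound 1 to compound 2 (0.05 log units; within the scatter), concerns the chlorophenyl on the amide-type nitrogen and did not move the number beyond the scatter.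

Compound 4 `C=CC(=O)Nc1cccc(NC(=O)CSc2nc(Nc3ccc(CC)cc3)c3ccccc3n2)c1` is not yet measured. It differs from compound 3 by 4-ethylphenyl in place of 3-bromophenyl on a nitrogen on an aromatic ring. For the measured compounds named here, no measured pair touches this position, so the step from compound 1 to compound 2 gives only indirect guidance: the one change tried left the read-out essentially unchanged, and nothing in the data points to a shift at the other aryl group either. Compound 4 is therefore expected to stay close to compound 3, with an expected step of no change at the digits printed from compound 3 to compound 4 (within the scatter), not beyond the scatter. The estimate for compound 4 in this assay is 15000 nM, within a range from 5000 nM to 45000 nM.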

Compound 4, half-maximal inhibitory concentration: 24300 nM
Estimate against measurement, compound 4: 1.6-fold (0.21 log units) below; low and high end bracket the measured number.
By their numbers in this assay, from the lowest: compounds 2, 1, 3 and 4 (each within the scatter of the next).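

Among the compounds shown here, this is the first measured step at the aryl group on the nitrogen on an aromatic ring: in this assay, 4-ethylphenyl in place of 3-bromophenyl gives a 1.6-fold higher number from compound 3 to compound 4 (0.21 log units; within the scatter). For the compounds shown here, the position therefore accepts a change of both the group and its place on the phenyl ring without the two compounds separating, much as the one step at the chlorophenyl on the amide-type nitrogen left its pair level. No measured information on these compounds bears on this result.

Because both features change at once, a single pair cannot separate them, and 4-bromophenyl would be needed to do so. Going by these compounds, it also remains open whether an amine, a carboxylic acid or a chain longer than ethyl on this phenyl ring would carry the number beyond the scatter.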